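The compounds below may be only part of what the source reports. "The series", "measured", "known", "first", "only" and "open" are said of these compounds alone.

Measured compounds:
Compound 1 `O=c1cc(CNCc2ccccc2Br)oc2ccc(O)c(O)c12`, in an ADME assay on Huh-7 cells (Homo sapiens) for cytotoxicity (a higher number here means that more compound is tolerated, a lower number that less compound is tolerated), a limit of the assay: > 100000 nM.
Compound 2 `O=c1cc(CNCc2cccc(O)c2)oc2ccc(O)c(O)c12`, in this assay, also a limit of the assay: > 100000 nM.
Compound 3 `O=c1cc(CNCc2ccc(O)cc2)oc2ccc(O)c(O)c12`, in this assay: 62700 nM.

Compound 3 is the only one of the three with an actual number in this assay; the other two values are limits (the limit of > 100000 nM in this assay, at which 2 of the 3 values shown sit). Compound 4 `Cc1ccc(CNCc2cc(=O)c3c(O)c(O)ccc3o2)cc1` differs from compound 3 by one change: methyl in place of hydroxy on an aromatic carbon. Going by the values given here, two measured steps touch the same position. In this assay the step of an at least 1.5-fold lower number from compound 1 to compound 3 (0.20 log units; that floor lies within the scatter) and the step of an at least 1.5-fold lower number from compound 2 to compound 3 (0.20 log units; that floor lies within the scatter) both end at compound 3, where the 4-hydroxyphenyl group enters, and their floors lie within the scatter; the step that the two limits leave unreadable from compound 1 to compound 2 cannot be read. Going from compound 3 to compound 4 removes that hydroxy again, so a move back toward the limit is expected, of a size the scatter may hide. Compound 4 is therefore expected to give about 100000 nM in this assay, between 40000 nM and 250000 nM. This estimate means an expected step of a 1.6-fold higher number from compound 3 to compound 4 (0.20 log units; within the scatter).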

Compound 4, half-maximal cytotoxic concentration: > 100000 nM
Compound 4 ended at the assay's limit; the forecaster's own chance of this, stated with the estimate: 50%; the middle value lies on the limit itself.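

In this assay compound 4 gives > 100000 nM, which is a limit of the assay. Going by these compounds alone, putting methyl in place of hydroxy on this aromatic carbon gives an at least 1.5-fold higher number from compound 3 to compound 4 (0.20 log units; that floor lies within the scatter), so this is the first direct comparison of two groups at this carbon, and it shows that a group counted with no hydrogen-bond donor or acceptor here still reaches the limit, though the floor of the step cannot be told apart from ordinary scatter. The steps to compound 4 from compound 1 and from compound 2 cannot be read, since both ends are limits.

Any real differences among the compounds stay hidden at one ceiling: the limit of > 100000 nM in this assay, at which 3 of the 4 values shown sit.

Still open, from the compounds shown here alone, is how an amine, a carboxylic acid or a longer chain at this carbon would read, and whether any of them would give a step clearly beyond the scatter.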